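From Allyloxy to Benzyloxy on a Shared Core

The compounds below may be only part of what the source reports. "The series", "measured", "known", "first", "only" and "open" are said of these compounds alone.

Of the compounds shown here, three on one core have been measured. Compound 1 `CC(C)CCOc1ccccc1C1CC(=O)c2ccccc2O1` gives 47.6% in a functional assay on RAW264.7 cells (Mus musculus) for inhibition, read by immunoassay, with a stated time of 12 h, tested at 30 uM; a lower number here means less inhibition, a higher number more inhibition at the concentration tested (going by the name of the read-out). Compound 2 `CC(C)c1ccc(COc2ccccc2C2CC(=O)c3ccccc3O2)cc1` gives 91.5% in this assay. Compound 3 `C=CCOc1ccccc1C1CC(=O)c2ccccc2O1` gives 49.3% in this assay, standing second highest of the three: close to compound 1, far below compound 2. Compound 4 `O=C1CC(c2ccccc2OCc2ccccc2)Oc2ccccc21` differs from compound 3 in one place: phenyl in place of vinyl on a saturated chain carbon bound to an oxygen on an aromatic ring. Among the measured compounds shown here, two measured steps bear on this change. The step of a number 43.9 percentage points higher from compound 1 to compound 2 (beyond the scatter) and the step of a number 42.2 percentage points lower from compound 2 to compound 3 (beyond the scatter) show that an aromatic ring on that chain carbon went with a large shift, while a number 1.7 percentage points higher from compound 1 to compound 3 (within the scatter) did not. A phenyl entering there is therefore expected to give a large rise, a number 25.7 percentage points higher from compound 3 to compound 4 (beyond the scatter). Compound 4 is estimated at 75%, between 55% and 92%.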

Compound 4, a percentage reported as inhibition, at one concentration (the size of the read-out at that concentration, not a potency): 93.2%
For compound 4 the middle estimate is 18.2 percentage points below the measured one; measured number above the stated range.
By their numbers in this assay, from the lowest: compounds 1 and 3 (each within the scatter of the next); then compounds 2 and 4 (each within the scatter of the next).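

In this assay the unsubstituted phenyl on that chain carbon carries the full rise, with a number 43.9 percentage points higher from compound 3 to compound 4 (beyond the scatter) and a number 45.6 percentage points higher from compound 1 to compound 4 (beyond the scatter) as its two large steps. Hydrogen in place of isopropyl on an aromatic carbon gives a number 1.7 percentage points higher from compound 2 to compound 4 (within the scatter) so, among these compounds, the isopropyl is not needed for the high inhibition. Nothing available explains this rise. From the compounds shown here alone, whether a pyridyl ring or a phenyl bearing an amine or a carboxylic acid would keep this level stays open. So does the effect of a longer chain between the oxygen and the phenyl.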